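The source may report more compounds than this note shows. Statements on the series, on what has been measured and on what is new or still open speak of the compounds shown alone.

Of the compounds shown here, three of one family have been measured in a functional assay on MCF7 cells (Homo sapiens) for cytotoxicity, read by MTT assay, with a stated time of 72 h; a higher number here means a weaker inhibitor of growth, a lower number a stronger inhibitor of growth. Compound 1 `CS/C(=N\C(=O)c1sccc1Cl)NC(=O)c1sccc1Cl` gives 10300 nM, and compound 2 `CS/C(=N\C(=O)c1ccno1)NC(=O)c1ccno1` gives 77800 nM. Compound 3 `C[Se]/C(=N\C(=O)c1ccco1)NC(=O)c1ccco1` gives 30 nM, the lowest of the three numbers: compound 1 lies well beyond the scatter above it, and compound 2 further still. Compound 3 is therefore the strongest growth inhibitor among the three measured.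

Compound 4 `CS/C(=N\C(=O)c1ccco1)NC(=O)c1ccco1` has not been measured. It differs from compound 3 in one place: a group of 2 heavy atoms (1 carbon, 1 sulfur; no ring) in place of a group of 2 heavy atoms (1 carbon, 1 selenium; no ring), on a carbon with a double bond to nitrogen. Within the data shown here, the two compounds that already carry the methylsulfanyl group, compound 1 and compound 2, both sit at much higher numbers than compound 3, but they also carry other ring systems, so no single measured step isolates this exchange. The expectation is still that the exchange weakens growth inhibition, with a step from compound 3 to compound 4 estimated at a 100-fold higher number from compound 3 to compound 4 (2.00 log units; beyond the scatter) in this assay. For compound 4 the value in this assay is estimated at 3000 nM, within a range from 300 nM to 30000 nM.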

Compound 4, concentration for 50% growth inhibition: 56100 nM
For compound 4 the middle estimate is 19-fold (1.27 log units) below the measured one; measured number above the stated range.
By their numbers in this assay, from the lowest: compound 3; then compound 1; then compounds 4 and 2 (each within the scatter of the next).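

Among these compounds, compound 3 and compound 4 differ in one place only, so this pair isolates the exchange that the earlier compounds could not: in this assay, methylsulfanyl entering in place of the selenium-bearing group gives a 1900-fold higher number from compound 3 to compound 4 (3.27 log units; beyond the scatter) on the shared core. Almost all of the growth inhibition seen with compound 3 is therefore tied to this one group on the carbon with a double bond to nitrogen, and a change of a single atom there is enough to lose it. Nothing at hand tells why this one atom matters so much.

On these data alone, whether a selenium-bearing group has the same effect on the cores of compound 1 and compound 2 remains open. So does the outcome at this carbon with a methoxy group, an amine or a longer chain such as ethylsulfanyl.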